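This account rests on a few compounds, and the source may have more. Where it says the series, first, only, none or still open, it means among the compounds named here.

Measured so far:
compound 1, `CCCN(CCC)c1cc(C(F)(F)F)ccc1CNC(=O)C(C)c1ccc(NS(C)(=O)=O)c(F)c1`, 0.3 nM in an assay on CHO cells for antagonist activity at transient receptor potential cation channel subfamily V member 1 (Homo sapiens), read by FLIPR; a lower number here means a stronger inhibitor, a higher number a weaker inhibitor
compound 2, `CC(C(=O)NCc1ccc(C(F)(F)F)cc1OC1CCCC1)c1ccc(NS(C)(=O)=O)c(F)c1`, 0.6 nM in this assay

Among the compounds with values here, only two compounds have numbers, and the one measured step is a 2.0-fold higher number from compound 1 to compound 2 (0.30 log units; within the scatter), which places compound 2 within the scatter of compound 1 rather than apart from it. Compound 2 is therefore not distinguished from compound 1 on these numbers; the two are indistinguishable.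

The next compound, compound 3, `CC(C(=O)NCc1ccc(C(F)(F)F)cc1OC1CCCCC1)c1ccc(NS(C)(=O)=O)c(F)c1`, keeps the whole of compound 2 except one change: cyclohexyl in place of cyclopentyl on an oxygen on an aromatic ring. Within the data shown here, no measured step concerns a ring-size change of this kind. Among the measured compounds shown here, the one step that touches the same part of the molecule, the step from compound 1 to compound 2, swapped an entire group there and stayed within the scatter, which suggests this region accepts variation without a clear effect on this assay. With nothing to suggest a shift, the expected step for compound 3 is a 1.3-fold higher number from compound 2 to compound 3 (0.12 log units; within the scatter), no further than the scatter allows. Compound 3 is therefore estimated at 0.8 nM, with a range from 0.3 nM to 2.5 nM.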

Compound 3, inhibition constant: 0.7 nM
For compound 3 the middle estimate is 1.1-fold (0.06 log units) above the measured one, within the range that was stated.
By their numbers in this assay, from the lowest: compounds 1, 2 and 3 (each within the scatter of the next, the first and the last beyond it).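

In this assay, cyclohexyl in place of cyclopentyl on an oxygen on an aromatic ring gives a 1.2-fold higher number from compound 2 to compound 3 (0.07 log units; within the scatter) and so cannot be told apart from the smaller ring, which shows that these two ring sizes are equally tolerated on that oxygen. The comparison with the dipropylamino compound gives a first, modest separation at this position, with cyclohexyloxy in place of dipropylamino giving a 2.3-fold higher number from compound 1 to compound 3 (0.37 log units; beyond the scatter) even though compound 2 stays within the scatter of compound 1. Nothing available offers an explanation for either step.

As far as these compounds go, it remains open how far this tolerance extends beyond these two rings. A smaller cyclobutyl ring, an open-chain isopropyl group or a ring containing an amine, such as piperidine, could show where the numbers begin to change clearly.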